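Replacing a substituted anilino arm with a methoxypyridinyl arm

The source may report more compounds than this note shows. Statements on the series, on what has been measured and on what is new or still open speak of the compounds shown alone.

In a functional assay on MCF7 cells (Homo sapiens) for cytotoxicity, read by sulforhodamine B assay, with a stated time of 72 h (on this read-out higher numbers stand for weaker inhibition and lower numbers for stronger inhibition), three compounds have been measured:
Compound 1 `CCS(=O)(=O)Nc1cc(-c2ccc3ncnc(Nc4ccc(F)cc4)c3c2)cnc1OC` gives 6510 nM.
Compound 2 `CCS(=O)(=O)Nc1cc(-c2ccc3ncnc(Nc4ccc(F)c(C(=O)OC)c4)c3c2)cnc1OC` gives 1150 nM.
Compound 3 `CCS(=O)(=O)Nc1cc(-c2ccc3ncnc(Nc4ccc(Cl)c(C(=O)OC)c4)c3c2)cnc1OC` gives 1430 nM.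

Compound 3 stands second highest of the three; its nearest neighbour is compound 2, separated by a 1.2-fold higher number from compound 2 to compound 3 (0.09 log units; within the scatter), and its furthest is compound 1, separated by a 4.6-fold lower number from compound 1 to compound 3 (0.66 log units; beyond the scatter). Compound 4 `CCS(=O)(=O)Nc1cc(-c2ccc3ncnc(Nc4ccc(OC)nc4)c3c2)cnc1OC` differs from compound 3 by 6-methoxypyridin-3-yl in place of 4-chloro-3-(methoxycarbonyl)phenyl on a nitrogen on an aromatic ring. The step that bears on this is a 5.7-fold lower number from compound 1 to compound 2 (0.75 log units; beyond the scatter), which shows that the methoxycarbonyl group, now removed, accounted for most of the drop from compound 1. Nothing measured speaks to the pyridine ring or its methoxy group. A rise back toward compound 1 is therefore expected, with wide uncertainty. Compound 4 is expected to give 5000 nM, between 1500 nM and 16000 nM. The estimated step is a 3.5-fold higher number from compound 3 to compound 4 (0.54 log units; beyond the scatter).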

Compound 4, half-maximal inhibitory concentration: 3770 nM
Estimate against measurement, compound 4: 1.3-fold (0.12 log units) above; low and high end bracket the measured number.
By their numbers in this assay, from the lowest: compounds 2 and 3 (each within the scatter of the next); then compounds 4 and 1 (each within the scatter of the next).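

In this assay, the 6-methoxypyridin-3-yl arm does not keep the lower numbers of the arms that carry methoxycarbonyl, with a 2.6-fold higher number from compound 3 to compound 4 (0.42 log units; beyond the scatter) and a 3.3-fold higher number from compound 2 to compound 4 (0.52 log units; beyond the scatter). Against the 4-fluorophenyl arm the picture differs: a 1.7-fold lower number from compound 1 to compound 4 (0.24 log units; within the scatter), so these two arms cannot be told apart here. No supporting data explain these results. Still open, on these data alone, is what a carboxylic acid or an amide would do in place of the methoxycarbonyl. So is whether the ring nitrogen or the methoxy group of the pyridine arm matters more.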